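Swapping Isopropyl for Oxan-4-yl on an Amide Carbonyl

The source may hold more compounds than are shown below. What is called first, only, known or untested is meant among the compounds shown, and "the series" means these compounds.

Of the compounds shown here, three have so far been measured in a physicochemical assay for lipophilicity, read by HPLC, measured as chromatographic lipophilicity, at pH 7.4; a higher number here means a more lipophilic compound, a lower number a more polar compound. Compound 1 `CC(C)(C)C(=O)N1CCNCC1c1ccccc1` gives 2.5, compound 2 `CC(C)C(=O)N1N=CCC1c1ccccc1` gives 4.4, and compound 3 `N#Cc1nccc(N2CCC(C(=O)N3N=CC[C@H]3c3cc(F)cc(F)c3)CC2)n1` gives 5.1. Compound 2 therefore holds the middle place of the three in this assay: its number stands beyond the usual scatter above that of compound 1 and beyond the scatter below that of compound 3.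

Compound 4 `O=C(C1CCOCC1)N1N=CCC1c1ccccc1` has not yet been measured. It differs from compound 2 in one place: oxan-4-yl in place of isopropyl on a carbonyl carbon. The group that enters is larger, carries one oxygen, forms a six-membered non-aromatic ring with one hetero atom, and counts one hydrogen-bond acceptor where the isopropyl group counted none.

Within the data shown here, no measured pair in this set shows this exact change, so the expectation rests on compound 2 alone. Starting from compound 2 at 4.4, the expected step in this assay is a number 0.70 log units lower from compound 2 to compound 4 (beyond the scatter), a decrease expected to exceed the scatter. Compound 4 is estimated at 3.7, with a range from 3.1 to 4.3.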

Compound 4, distribution coefficient: 3.1
Compound 4: the middle estimate sits 0.60 log units above what was measured, within the range that was stated.
By their numbers in this assay, from the lowest: compound 1; then compound 4; then compound 2; then compound 3.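

With this pair, the set gains its first comparison of two compounds that differ in one place: in this assay, placing oxan-4-yl instead of isopropyl on the carbonyl carbon gives a number 1.30 log units lower from compound 2 to compound 4 (beyond the scatter) on the shared core. The size of this step shows that the read-out at this position responds strongly to the group attached there. No separate measurement bears on why the number moves, and the larger size, the ring and the oxygen of oxan-4-yl remain untangled.

The compounds shown leave open how much of the step would remain with cyclohexyl, which keeps a six-membered ring but carries no oxygen. They also leave open what a piperidin-4-yl group, with a ring nitrogen where oxan-4-yl has its oxygen, would give on the same carbonyl carbon.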